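The source may report more compounds than this note shows. Statements on the series, on what has been measured and on what is new or still open speak of the compounds shown alone.

Measured so far in an ADME assay on the whole organism (Mus musculus, strain BALB/c) for pharmacokinetics, read by LC-MS, with a stated time of 24 h, at a dose of 10 mg/kg by the oral route; on this read-out lower numbers stand for lower exposure and higher numbers for higher exposure at the dose given:
- compound 1 `Cn1nccc1-c1cc(C(F)(F)F)ccc1[C@H]1CCOc2cc(S(=O)(=O)Nc3nccs3)ccc21` gives 6000 nM
- compound 2 `Cn1nccc1-c1cc(C(F)(F)F)ccc1[C@H]1CCOc2cc(S(=O)(=O)Nc3ncccn3)ccc21` gives 15000 nM

Compound 1 holds the lower of these two numbers. Among the measured compounds shown here, the one measured step, a 2.5-fold higher number from compound 1 to compound 2 (0.40 log units; beyond the scatter), puts pyrimidin-2-yl in place of 1,3-thiazol-2-yl on a sulfonamide nitrogen.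

Compound 3 `O=S(=O)(Nc1nccs1)c1ccc2c(c1)OCC[C@@H]2c1ccc(C(F)(F)F)cc1-n1ccnn1` keeps the 1,3-thiazol-2-yl of compound 1 and differs elsewhere: 1H-1,2,3-triazol-1-yl in place of 1-methyl-1H-pyrazol-5-yl on an aromatic carbon. One five-membered aromatic ring therefore replaces another, on an aromatic carbon. For the measured compounds named here, no measured pair of compounds shows a change at this place, so the data give no direction for it. The step of a 2.5-fold higher number from compound 1 to compound 2 (0.40 log units; beyond the scatter) bears on it only indirectly, as a sense of how far the exchange of one ring for another moved this number at a different place in the molecule. With no direction to go on, the expectation is no step beyond the scatter, held with little confidence. The estimated change is a 1.2-fold lower number from compound 1 to compound 3 (0.08 log units; within the scatter). For compound 3 the expected value is 5000 nM, with an estimated range from 1500 nM to 15000 nM.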

Compound 3, maximal plasma concentration: 3000 nM
The estimate for compound 3 lay 1.7-fold (0.22 log units) above the measured number; low and high end bracket the measured number.
By their numbers in this assay, from the lowest: compounds 3 and 1 (each within the scatter of the next); then compound 2.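

In this assay, among the compounds shown here, the first reading at this place, on an aromatic carbon ortho to a large group, is a 2.0-fold lower number from compound 1 to compound 3 (0.30 log units; within the scatter) when 1H-1,2,3-triazol-1-yl takes the place of 1-methyl-1H-pyrazol-5-yl. So this exchange of one five-membered aromatic ring for another, which also brings one more ring nitrogen, cannot be told apart from no effect on maximal plasma concentration, whereas the exchange on the sulfonamide nitrogen, a 2.5-fold higher number from compound 1 to compound 2 (0.40 log units; beyond the scatter), stands beyond the scatter; a single pair at each place, however, sets no rule for either. No measurement at hand offers an explanation for this reading.

The compounds shown leave open whether a group of a different kind at this place, such as an amine or a carboxylic acid, would move the number beyond the scatter, since both groups seen here are five-membered aromatic rings. They also leave open how 1H-1,2,3-triazol-1-yl would behave with pyrimidin-2-yl on the sulfonamide nitrogen. For the compounds shown here, each of these two changes is seen only on its own against compound 1.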